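The compounds below may be only part of what the source reports. "The series", "measured", "known", "first", "only" and "open" are said of these compounds alone.

Series notes, measured in an ADME assay on L02 cells (Homo sapiens) for cytotoxicity, read by MTT assay, with a stated time of 24 h; a higher number here means a weaker inhibitor, a lower number a stronger inhibitor:

- compound 1 `COc1cc(/C=C2\CN(C)C/C(=C\c3ccc(Cl)cc3)C2=O)cc(OC)c1` gives 18900 nM in this series
- compound 2 `COc1cc(/C=C2\CN(C)C/C(=C\c3cc(OC)c(OC)c(OC)c3)C2=O)cc(OC)c1` gives 14600 nM in this series

Compound 2 stands within the scatter of compound 1, so the two numbers do not separate these compounds. Compound 3 `COc1cc(/C=C2\CN(C)C/C(=C\c3ccc(Cl)cc3)C2=O)cc(OC)c1OC` is the next to be read. Its difference from compound 2 is 4-chlorophenyl in place of 3,5-dimethoxyphenyl on a double-bonded chain carbon bound to a double-bonded ring carbon and consists of 4-chlorophenyl in place of 3,5-dimethoxyphenyl on a double-bonded chain carbon bound to a double-bonded ring carbon. Among the compounds with values here, no single-place step between measured compounds is available to size this change. Compound 1, which also carries 4-chlorophenyl, gives 18900 nM in the same read-out, so no step beyond the scatter is expected in either direction. The expected change is a 1.1-fold higher number from compound 2 to compound 3 (0.04 log units; within the scatter) and would stay within the scatter. Compound 3 is estimated at 16000 nM with an expected range from 7500 nM to 35000 nM in this assay for now.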

Compound 3, half-maximal inhibitory concentration: 14000 nM
Compound 3: middle estimate off by 1.1-fold (0.06 log units), on the high side, and the stated range covers the measured number.
By their numbers in this assay, from the lowest: compounds 3, 2 and 1 (each within the scatter of the next).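

In this assay, 4-chlorophenyl in place of 3,5-dimethoxyphenyl on a double-bonded chain carbon bound to a double-bonded ring carbon now has a measured size: a 1.0-fold lower number from compound 2 to compound 3 (0.02 log units; within the scatter). Methoxy in place of hydrogen on an aromatic carbon can also be sized for the first time, at a 1.4-fold lower number from compound 1 to compound 3 (0.13 log units; within the scatter), so neither single-place step separates the compounds in this read-out. No measured evidence bears on this result.

The aromatic groups shown carry only methoxy or chlorine, so it remains open whether an amine or a carboxylic acid on an aromatic carbon would give a step beyond the scatter. On these data alone, it also remains open whether a longer chain in place of methoxy would do so.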